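Working notes: methyl-to-hydrogen step in a small series

A few compounds are considered here, and "the series" means these few. Any claim that something is new, unique, unknown or untested is made for them only; others in the source may bear on it.

Measured compounds:
compound 1 `O=C(CCc1ccccc1)Nc1ccc(-c2nc3ccccc3[nH]2)cc1`; in an assay on cells for inhibition of matrix metalloproteinase-9 (Homo sapiens), read by fluorescence, with stated times of 15 min and 4 h (on this read-out lower numbers stand for stronger inhibition and higher numbers for weaker inhibition), compound 1 gives 29000 nM
compound 2 `Cc1ccc2nc(-c3ccc(NC(=O)CCc4ccccc4)cc3)[nH]c2c1`; in this assay compound 2 gives 60000 nM
compound 3 `Cc1ccc2nc(-c3ccc([N+](=O)[O-])cc3)[nH]c2c1`; in this assay compound 3 gives 22000 nM

Compound 2 and compound 1 differ in one place only, (hydrogen in place of methyl on an aromatic carbon). The step in this assay is a 2.1-fold lower number from compound 2 to compound 1 (0.32 log units; beyond the scatter).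

The difference between the core of compound 2 and the core of compound 3 is not broken down here. What the two values show is that compound 3 gives a lower number than compound 2 in this assay, beyond the scatter, while compound 3 and compound 1 lie within the scatter of each other, so no order between those two is claimed.

Compound 4 `O=[N+]([O-])c1ccc(-c2nc3ccccc3[nH]2)cc1` has not yet been measured in this assay. It differs from compound 3 by hydrogen in place of methyl on an aromatic carbon, which is the same change as from compound 2 to compound 1. Among the measured compounds shown here, the step from compound 3 to compound 4 is expected to be a 2.0-fold lower number from compound 3 to compound 4 (0.30 log units; within the scatter), in the same direction and of about the same size as the one prior instance, because that instance gave a 2.1-fold lower number from compound 2 to compound 1 (0.32 log units; beyond the scatter). Resting on a single earlier pair, the range is kept wide. Compound 4 is estimated at 11000 nM in this assay, between 4500 nM and 28000 nM.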

Compound 4, half-maximal inhibitory concentration: 56500 nM
Compound 4: the middle estimate sits 5.1-fold (0.71 log units) below what was measured; measured number outside the range, above it.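

In this assay hydrogen in place of methyl gives a 2.6-fold higher number from compound 3 to compound 4 (0.41 log units; beyond the scatter) and thus a step opposite in direction to the one seen on the amide-bearing core. The change therefore did not carry over from one core to the other in this series, in direction or in size, and the two steps differ by more than scatter: the same change on two cores in this assay, a 2.1-fold lower number (0.32 log units; beyond the scatter) from compound 2 to compound 1 and a 2.6-fold higher number (0.41 log units; beyond the scatter) from compound 3 to compound 4, 5.3-fold (0.73 log units) apart, beyond the scatter of two such steps

Among the compounds shown here, with only two pairs, this does not show which feature of the cores sets the direction of the step, nor how the step would run on any further core. It also gives no general rule for the methyl group in this series, in either direction.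

The compounds shown leave open how the same change runs on cores carrying an amine or a carboxylic acid in place of the nitro group or the amide chain. Also open, as far as these compounds go, is what an ethyl or a methoxy group in place of the methyl would give on each of the two cores.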